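This account rests on a few compounds, and the source may have more. Where it says the series, first, only, none or still open, it means among the compounds named here.

Measured compounds in the series:
- compound 1, `CCC1(CC)CC(S(=O)(=O)c2ccc(F)cc2)=C(c2ccc(/C(N)=N/O)cc2)O1`, 91400 nM
- compound 2, `CC1(Cc2cccc(C(F)(F)F)c2)CC(S(=O)(=O)c2ccc(F)cc2)=C(c2ccc(/C(N)=N/O)cc2)O1`, 49800 nM
- compound 3, `CC1(Cc2cc(C(F)(F)F)cc(C(F)(F)F)c2)CC(S(=O)(=O)c2ccc(F)cc2)=C(c2ccc(/C(N)=N/O)cc2)O1`, 43100 nM

All three numbers were read in an ADME assay on cells (Peritoneal macrophage, Mus musculus, strain Balb/c) for cytotoxicity, read by resazurin assay, with a stated time of 72 h; a higher number here means that more compound is tolerated, a lower number that less compound is tolerated. The three values lie within the usual scatter of one another, so no ranking among them is supported. Compound 2 has its nearest neighbour in compound 3, and its wider gap is to compound 1, whose value of 91400 nM still falls within the scatter of the value of compound 2.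

Compound 4, `Cc1ccc(CC2(C)CC(S(=O)(=O)c3ccc(F)cc3)=C(c3ccc(/C(N)=N/O)cc3)O2)cc1`, has not yet been measured in this assay. It differs from compound 2 by 4-methylphenyl in place of 3-(trifluoromethyl)phenyl on a saturated chain carbon bound to a saturated ring carbon. Among the measured compounds shown here, the only measured step that touches the same benzyl substituent is the one from compound 2 to compound 3, a 1.2-fold lower number from compound 2 to compound 3 (0.06 log units; within the scatter), in which a trifluoromethyl was added without any shift beyond the scatter. Swapping one small aromatic substituent pattern for another at the same benzyl position is therefore expected to leave the number roughly where compound 2 sits, with no step beyond the scatter anticipated, a 1.0-fold higher number from compound 2 to compound 4 (0.00 log units; within the scatter). For compound 4 the expected value in this assay is 50000 nM, with a range from 25000 nM to 100000 nM.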

Compound 4, half-maximal cytotoxic concentration: 54400 nM
For compound 4 the middle estimate is 1.1-fold (0.04 log units) below the measured one; the range from low to high includes it.
By their numbers in this assay, from the lowest: compounds 3, 2, 4 and 1 (each within the scatter of the next, the first and the last beyond it).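

In this assay, 4-methylphenyl in place of 3-(trifluoromethyl)phenyl on a saturated chain carbon bound to a saturated ring carbon gives a 1.1-fold higher number from compound 2 to compound 4 (0.04 log units; within the scatter), so this position tolerates loss of all fluorine from the aryl group without a shift beyond the scatter. The earlier step at this substituent only added a trifluoromethyl (a 1.2-fold lower number from compound 2 to compound 3 (0.06 log units; within the scatter)), whereas the new one goes from 10 heavy atoms to 7 in the exchanged group and likewise stays within the scatter. No measurement shown here accounts for this result.

The aryl groups shown at this position carry only trifluoromethyl or methyl, so the reading with an amine or a carboxylic acid on that ring stays open. On these data alone, a longer chain in place of the benzyl substituent also remains open.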